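Chloro in place of fluoro: compound 3 to compound 4

The source may report more compounds than this note shows. Statements on the series, on what has been measured and on what is new or still open speak of the compounds shown alone.

Measured in a functional assay on MGC-803 cells (Homo sapiens) for inhibition, read by MTT assay, with a stated time of 48 h; a higher number here means a weaker inhibitor, a lower number a stronger inhibitor:
compound 1 `Cc1ccc(NC(=S)NC(=O)c2ccc(OCc3cccc(Cl)c3)cc2)cc1-c1nc2ccccc2[nH]1`: 51300 nM
compound 2 `O=C(NC(=S)Nc1ccc(Cl)c(-c2nc3ccccc3[nH]2)c1)c1ccc(OCc2ccc(C(F)(F)F)cc2)cc1`: 5330 nM
compound 3 `Cc1ccc(NC(=O)NC(=O)c2ccc(OCc3ccccc3F)cc2)cc1-c1nc2ccccc2[nH]1`: 2520 nM

Compound 3 gives the lowest number of the three in this assay. Its nearest neighbour is compound 2, at a gap beyond the scatter, and compound 1 stands furthest away, well beyond it. With both gaps beyond the scatter, compound 3 is the strongest inhibitor of the set shown.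

Compound 4 `Cc1ccc(NC(=O)NC(=O)c2ccc(OCc3ccccc3Cl)cc2)cc1-c1nc2ccccc2[nH]1` is not yet measured. It differs from compound 3 in one place: chloro in place of fluoro on an aromatic carbon, so that the (2-fluorobenzyl)oxy arm becomes (2-chlorobenzyl)oxy. Within the data shown here, no measured pair in the set isolates this change, so the size of the step rests on expectation alone. A small step is expected, within the scatter of this assay and with no firm direction; the estimated step is a 1.1-fold lower number from compound 3 to compound 4 (0.06 log units; within the scatter). Compound 4 is expected to give about 2200 nM, with a likely range from 800 nM to 6000 nM.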

Compound 4, half-maximal inhibitory concentration: 19500 nM
Compound 4: the middle estimate sits 8.9-fold (0.95 log units) below what was measured; the measured number lies above the stated range.
By their numbers in this assay, from the lowest: compound 3; then compound 2; then compound 4; then compound 1.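

In this assay, the change from 2-fluorobenzyl to 2-chlorobenzyl gives a 7.7-fold higher number from compound 3 to compound 4 (0.89 log units; beyond the scatter), so the series is sensitive to which halogen sits at this place on the benzyl arm. This is the only pair shown that differs in one place; compounds 1, 2 and 3 differ from one another in several places and could not isolate the effect of this halogen. Nothing available accounts for the size of this step.

Still open, from the compounds shown here alone, is how the same place responds to a bare hydrogen, a methoxy group or a nitrile, which would show whether fluoro is specifically favoured or chloro specifically disfavoured. Also open, going by these compounds, is whether the same exchange produces a similar step on the thiocarbonyl linker of compound 1.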